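Ring Swap on the Shared Nitrogen: From Compound 2 to Compound 3

A few compounds are considered here, and "the series" means these few. Any claim that something is new, unique, unknown or untested is made for them only; others in the source may bear on it.

Measured so far:
- Compound 1, `CCC[C@@H](NC(=O)c1nccs1)c1cnc(Nc2cccnc2)c(Cl)c1`: 71.4 nM
- Compound 2, `CCC[C@@H](NC(=O)c1nccs1)c1cnc(Nc2cnc(C)s2)c(Cl)c1`: 60 nM

Both compounds were tested in a functional assay on HEK293 cells for negative allosteric modulation of metabotropic glutamate receptor 5 (Homo sapiens), read by HTRF and inositol phosphate accumulation; a lower number here means a stronger inhibitor, a higher number a weaker inhibitor. Compound 1 gives 71.4 nM there, and compound 2 gives 60 nM. Compound 2 carries the lower of the two numbers, yet the step of a 1.2-fold lower number from compound 1 to compound 2 (0.08 log units; within the scatter) lies within the scatter, so the two cannot be told apart on these data.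

Compound 3 `CCC[C@@H](NC(=O)c1nccs1)c1cnc(Nc2cnc(C)nc2)c(Cl)c1` has not yet been measured. It differs from compound 2 in a single place: 2-methylpyrimidin-5-yl in place of 2-methyl-1,3-thiazol-5-yl on a nitrogen on an aromatic ring. Among the compounds with values here, the only measured step that speaks to this position is a 1.2-fold lower number from compound 1 to compound 2 (0.08 log units; within the scatter), which exchanged the ring on the same nitrogen and stayed within the scatter. No change beyond the scatter has been seen at this position, so for compound 3 the expected step in this assay is a 1.5-fold higher number from compound 2 to compound 3 (0.18 log units; within the scatter). Compound 3 is therefore estimated at 90 nM, with a range from 35 nM to 250 nM.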

Compound 3, half-maximal inhibitory concentration: 43.9 nM
For compound 3 the middle estimate is 2.1-fold (0.31 log units) above the measured one; measured number inside the range.
By their numbers in this assay, from the lowest: compounds 3, 2 and 1 (each within the scatter of the next).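

In this assay the exchange of 2-methyl-1,3-thiazol-5-yl for 2-methylpyrimidin-5-yl gives a 1.4-fold lower number from compound 2 to compound 3 (0.14 log units; within the scatter) and the exchange of pyridin-3-yl for 2-methylpyrimidin-5-yl gives a 1.6-fold lower number from compound 1 to compound 3 (0.21 log units; within the scatter) on the same nitrogen. A third aromatic ring has now stood at this place, and all three compounds remain within the scatter of one another, so the position has so far accepted both a five-membered and a six-membered ring without a change that can be read. No measured property is at hand to explain this.

The compounds shown leave open whether this holds beyond such aromatic rings, for instance with a saturated piperidine ring or a plain butyl chain on the nitrogen. Going by these compounds, it is also open whether an amine or a carboxylic acid in place of the methyl group on the ring would shift the number beyond the scatter.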